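Trading Two Methoxy Arms for Cyanoethyl and Cyclopropyl

The source may report more compounds than this note shows. Statements on the series, on what has been measured and on what is new or still open speak of the compounds shown alone.

Measured so far:
Compound 1, `COCC(COC)Nc1nc(C)nc2c(-c3ccc(OC)cc3C)c(C)nn12`: 9.7 nM
Compound 2, `CCCC(C)Nc1nc(C)nc2c(-c3c(C)cc(OC)cc3OC)c(C)nn12`: 2.14 nM

Both numbers come from an assay on cell membranes for displacement of a labelled ligand from corticotropin-releasing factor receptor 1 (Rattus norvegicus); on this read-out higher numbers stand for weaker inhibition and lower numbers for stronger inhibition. Of the two, compound 1 stands at the higher number, and compound 2 sits at a lower one, a gap beyond the usual scatter. Since the two differ in several places at once, nothing more than these two values can be said about that pair.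

Compound 3, `COc1ccc(-c2c(C)nn3c(N(CCC#N)C4CC4)nc(C)nc23)c(C)c1`, has not yet been measured. Compared with compound 1 it carries (2-cyanoethyl)(cyclopropyl)amino in place of (2-methoxy-1-(methoxymethyl)ethyl)amino on an aromatic carbon. For the measured compounds named here, no measured pair isolates this change, so the expectation rests on compound 1 alone. From compound 1 to compound 3 a step of a 1.6-fold lower number from compound 1 to compound 3 (0.21 log units; within the scatter) is expected, a modest lowering that may not clear the usual scatter. Compound 3 is therefore estimated at 6 nM, with a likely range from 1.5 nM to 25 nM.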

Compound 3, half-maximal inhibitory concentration: 1.88 nM
Beside the measured number, compound 3's estimate is 3.2-fold (0.50 log units) above it; measured number inside the range.
By their numbers in this assay, from the lowest: compounds 3 and 2 (each within the scatter of the next); then compound 1.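

In this assay, putting (2-cyanoethyl)(cyclopropyl)amino in place of (2-methoxy-1-(methoxymethyl)ethyl)amino gives a 5.2-fold lower number from compound 1 to compound 3 (0.71 log units; beyond the scatter). For the compounds shown here, this is the first comparison here that isolates one place, and it shows that the group on this aromatic carbon, between two ring nitrogen atoms, can change the number on its own. The position also accepts a group with a nitrile and a three-membered ring, and with neither oxygen atom nor the amine hydrogen of the group it replaces, without any loss of inhibition; no measurement here explains why the number falls.

As far as these compounds go, the nitrile, the cyclopropyl ring and the loss of the methoxy arms all change together, so their separate shares stay open. A plain propyl chain in place of the 2-cyanoethyl arm would begin to separate them.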